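The compounds below may be only part of what the source reports. "The series", "measured", "known", "first", "only" and "open" are said of these compounds alone.

Measured in an ADME assay on microsomes from liver (Rattus norvegicus) for metabolic stability, read by LC-MS, tested at 1 mM; a lower number here means that the compound disappears faster, a higher number that the compound lasts longer:
- compound 1 `N#Cc1ccc(F)cc1Cn1c(N2CCC[C@@H](N)C2)nc2cc[nH]c2c1=O`: > 1 h (a limit of the assay, not a number)
- compound 2 `CS(=O)(=O)c1ccc(-c2c[nH]c3c(=O)n(Cc4cc(F)ccc4C#N)c(N4CCC[C@@H](N)C4)nc23)c(F)c1`: 1.59 h

In this assay, for the measured compounds named here, compound 2 gives 1.59 h, the only true number so far. Compound 1 is known only through a limit, (the limit of > 1 h in this assay, at which 1 of the 2 values shown sits).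

Compound 3 `CS(=O)(=O)c1cccc(-c2c[nH]c3c(=O)n(Cc4cc(F)ccc4C#N)c(N4CCC[C@@H](N)C4)nc23)c1` is not yet measured. It carries 3-(methylsulfonyl)phenyl in place of 2-fluoro-4-(methylsulfonyl)phenyl on an aromatic carbon of a five-membered aromatic ring with 1 nitrogen, part of a fused or bridged system of two rings, two ring bonds from the ring nitrogen: 3-(methylsulfonyl)phenyl in place of 2-fluoro-4-(methylsulfonyl)phenyl on an aromatic carbon.

Going by the values given here, the one measured step that bears on this place is a step that the limit leaves unreadable from compound 1 to compound 2. Among the compounds with values here, it introduced the group that now changes, but it gives no size to carry over, and no measured step isolates the loss of the fluorine. No shift beyond the scatter is therefore expected in this assay, and no direction can be assigned. The estimated change is a 1.1-fold lower number from compound 2 to compound 3 (0.03 log units; within the scatter), expected to stay within the scatter. Compound 3 is expected at 1.5 h, with an estimated range of 0.75 h to 3.2 h.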

Compound 3, half-life: 1.65 h
The estimate for compound 3 lay 1.1-fold (0.04 log units) below the measured number, within the range that was stated.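

In this assay, 3-(methylsulfonyl)phenyl in place of 2-fluoro-4-(methylsulfonyl)phenyl gives a 1.0-fold higher number from compound 2 to compound 3 (0.02 log units; within the scatter). For the compounds shown here, this is the first readable step at this aromatic carbon, and it shows that removing the fluorine and moving the methylsulfonyl group on the phenyl ring, taken together, leave the half-life within the scatter. Compound 1 is known only through a limit, so the steps from it to compound 2 and to compound 3 cannot be read: the limit of > 1 h in this assay, at which 1 of the 3 values shown sits.

From the compounds shown here alone, the pair does not separate the loss of the fluorine from the move of the methylsulfonyl group, so the two changes could each matter on their own or neither could, and the effect of placing any aryl group on this carbon stays unknown without a number for compound 1. Also open, going by these compounds, is how the half-life responds at this position to a substituent other than methylsulfonyl on the phenyl ring, such as a carboxylic acid or an amine, or to a plain unsubstituted phenyl.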